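This account rests on a few compounds, and the source may have more. Where it says the series, first, only, none or still open, it means among the compounds named here.

In an ADME assay on LLC-MK2 cells (Macaca mulatta) for cytotoxicity, read by spectrophotometry and crystal violet staining, with a stated time of 4 days (a higher number here means that more compound is tolerated, a lower number that less compound is tolerated), compound 1 `CC(C)n1ncc2c(C(=O)Nc3cccc(F)c3)cc(-c3cccs3)nc21` gives > 200000 nM, a limit of the assay and not a number. Compound 2 `CC(C)n1ncc2c(C(=O)Nc3ccc(F)c(F)c3)cc(-c3cccs3)nc21` gives > 200000 nM, again only a limit: the limit of > 200000 nM in this assay, at which 2 of the 2 values shown sit. Compound 3 `CC(C)n1ncc2c(C(=O)Nc3cc(C(N)=O)ccc3F)cc(-c3cccs3)nc21` carries 5-carbamoyl-2-fluorophenyl in place of 3,4-difluorophenyl on an amide-type nitrogen, (5-carbamoyl-2-fluorophenyl in place of 3,4-difluorophenyl on an amide-type nitrogen). Going by the values given here, the one measured step that bears on this change, a step that the two limits leave unreadable from compound 1 to compound 2, has no size to carry over. No shift beyond the scatter is therefore expected in this assay, and the estimated step is a number no higher from compound 2 to compound 3 (the limit leaves the size open). The expected value for compound 3 is 200000 nM, within an estimated range of 100000 nM to 300000 nM.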

Compound 3, half-maximal cytotoxic concentration: 25000 nM
For compound 3 the middle estimate is 8.0-fold (0.90 log units) above the measured one; measured number outside the range, below it.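

Putting 5-carbamoyl-2-fluorophenyl on the amide-type nitrogen gives an at least 8.0-fold lower number from compound 2 to compound 3 (0.90 log units; beyond the scatter) and an at least 8.0-fold lower number from compound 1 to compound 3 (0.90 log units; beyond the scatter). The group at this place can therefore move the result in this assay, which the two fluorophenyl compounds alone could not show: the limit of > 200000 nM in this assay, at which 2 of the 3 values shown sit.

This change alters the fluoro pattern and adds a carbamoyl group together, and the compounds shown do not separate the two. Going by these compounds, whether a carboxylic acid or a nitrile in place of the carbamoyl group would lower the number as well remains open.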